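The source may report more compounds than this note shows. Statements on the series, on what has been measured and on what is new or still open speak of the compounds shown alone.

Working notes on the series.

Of the compounds shown here, three have been measured in an assay on microsomes from liver for inhibition of sterol O-acyltransferase 1 (Rattus norvegicus), tested at 50 ug/mL; a lower number here means less inhibition, a higher number more inhibition at the concentration tested (going by the name of the read-out). Compound 1 `CCCCCCCN(CCCCCSc1cc(-c2ccccc2)cnn1)C(=O)Nc1ccc(F)cc1F` gives 75%. Compound 2 `CCCCCCCN(CCCCC[S+]([O-])c1cc(-c2ccccc2)c(-c2ccccc2)nn1)C(=O)Nc1ccc(F)cc1F` gives 65%. Compound 3 `CCCCCCCN(CCCCCS(=O)(=O)c1cc(-c2ccccc2)c(-c2ccccc2)nn1)C(=O)Nc1ccc(F)cc1F` gives 70%, which places it second highest of the three numbers, with compound 1 five points higher and compound 2 five points lower, both within the scatter. Within the data shown here, no single-point step between these measured compounds exists, so the three values are read only as a group that sits close together.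

Compound 4 `CCCCCCCN(CCCCCS(=O)(=O)c1cc(-c2ccccc2)cnn1)C(=O)Nc1ccc(F)cc1F` has not yet been measured in this assay. Relative to compound 3 the change is hydrogen in place of phenyl on an aromatic carbon, on an aromatic carbon of a six-membered aromatic ring with two nitrogen, ortho to a phenyl group.

Because compound 1 gives 75% while also carrying a single phenyl group on this ring, and because compound 3 gives 70%, no step beyond the scatter is expected; the step from no change at the digits printed from compound 3 to compound 4 (within the scatter) is estimated as essentially flat. For compound 4 the expected value in this assay is 70%, within a range of 55% to 85%.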

Compound 4, a percentage reported as inhibition, at one concentration (the size of the read-out at that concentration, not a potency): 67%
The estimate for compound 4 lay 3 percentage points above the measured number; the range from low to high includes it.
By their numbers in this assay, from the lowest: compounds 2, 4, 3 and 1 (each within the scatter of the next).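

In this assay, hydrogen in place of phenyl on an aromatic carbon, ortho to a phenyl group, gives a number 3 percentage points lower from compound 3 to compound 4 (within the scatter). Among these compounds, this is the first comparison that isolates a single place, and it shows that at this position the read-out at the concentration tested does not depend on the presence of the phenyl group, with its 6 heavy atoms. Nothing available gives a reason for this result.

What an amine or a carboxylic acid on this same aromatic carbon would do remains open, so the number in this assay is shown to be level only for hydrogen and phenyl. On these data alone, because the read-out comes from one concentration, it also remains open whether compound 3 and compound 4 would differ in potency.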